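Urea capping of an anilino nitrogen on a biphenyl core

This account rests on a few compounds, and the source may have more. Where it says the series, first, only, none or still open, it means among the compounds named here.

Compound 3 `CN(C)c1ccc(-c2cccc(N)c2)cc1` gives 100000 nM in an assay on COS-7 cells for inhibition of patatin-like phospholipase domain-containing protein 2 (Mus musculus) (a higher number here means a weaker inhibitor, a lower number a stronger inhibitor), the higher of the two plain numbers shown; compound 1 `CCOc1ccc(-c2cccc(NC(=O)N(C)C)c2)cc1` gives 70000 nM, within the scatter of it. Compound 2 `CN(C)c1ccc(-c2cccc([N+](=O)[O-])c2)cc1` reaches only the limit > 200000 nM, not a number. Within the data shown here, the one measured step at this nitrogen, an at least 2.0-fold lower number from compound 2 to compound 3 (0.30 log units; that floor lies within the scatter), sits at a floor that the limit of > 200000 nM in this assay, at which 1 of the 3 values shown sits, sets. Compound 4 `CN(C)C(=O)Nc1cccc(-c2ccc(N(C)C)cc2)c1` differs from compound 3 by dimethylcarbamoyl in place of hydrogen on a nitrogen on an aromatic ring. Among the measured compounds shown here, no measured step covers this change directly, and the single step nearby is small, so the number for compound 4 is expected to move only within the scatter, the estimated step being a 1.4-fold lower number from compound 3 to compound 4 (0.15 log units; within the scatter). Compound 4 is therefore estimated at 70000 nM, with a range from 25000 nM to 200000 nM.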

Compound 4, half-maximal inhibitory concentration: < 5000 nM
Compound 4: a limit, no number; the forecaster's own chance of this, stated with the estimate: 25%; at least 14-fold (1.14 log units) between middle value and limit.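

In this assay, the urea cap on the anilino nitrogen has a large effect: dimethylcarbamoyl in place of hydrogen gives an at least 20-fold lower number from compound 3 to compound 4 (1.30 log units; beyond the scatter), and (dimethylcarbamoyl)amino in place of nitro gives an at least 40-fold lower number from compound 2 to compound 4 (1.60 log units; beyond the scatter). The urea alone does not account for this, as dimethylamino in place of ethoxy, with the urea kept, gives an at least 14-fold lower number from compound 1 to compound 4 (1.14 log units; beyond the scatter). Compound 4 stands at a limit, not a number: the limit of < 5000 nM in this assay, at which 1 of the 4 values shown sits. The compounds shown leave open how far the number actually falls, and whether a longer chain on the urea nitrogen, or a carboxylic acid in place of the urea, would keep it there.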